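A few compounds are considered here, and "the series" means these few. Any claim that something is new, unique, unknown or untested is made for them only; others in the source may bear on it.

Of the compounds shown here, two have been measured here. Compound 1 `CC(C)c1ccc(N2N=C(C(C)(C)C)CC2c2ccc(O)cc2)cc1` gives 54.9% in an assay on isolated protein for inhibition of protein kinase C zeta type (Homo sapiens), with a stated time of 4 min, tested at 62.5 uM; a lower number here means less inhibition, a higher number more inhibition at the concentration tested (going by the name of the read-out). Compound 2 `Oc1ccc(C2CC(c3ccccc3O)=NN2c2ccc(Cl)cc2)cc1` gives 92% in this assay, the higher of the two numbers by a margin that lies beyond the usual scatter, and so compound 2 stands at the top of this small set.

The next step moves from compound 2 to compound 3 `CCOc1ccccc1C1=NN(c2ccc(Cl)cc2)C(c2ccc(O)cc2)C1`. The two structures differ in one place: ethyl in place of hydrogen on an oxygen on an aromatic ring. Everything else in the molecule stays as it is, so only the hydroxy group that becomes an ethoxy group carries the change.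

Going by the values given here, no pair of measured compounds shows this kind of change, so there is no earlier step to lean on. The expectation is that compound 3 keeps a good part of the inhibition of compound 2 but does not quite reach it, with a step of a number 22 percentage points lower from compound 2 to compound 3 (beyond the scatter) expected in this assay. Compound 3 is therefore estimated at about 70%, with a likely range from 40% to 95% in this assay.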

Compound 3, a percentage reported as inhibition, at one concentration (the size of the read-out at that concentration, not a potency): 42.8%
Compound 3: the middle estimate sits 27.2 percentage points above what was measured; the range from low to high includes it.
By their numbers in this assay, from the lowest: compound 3; then compound 1; then compound 2.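

Replacing the hydroxy group of compound 2 with an ethoxy group, so that 2-hydroxyphenyl becomes 2-ethoxyphenyl, gives a number 49.2 percentage points lower from compound 2 to compound 3 (beyond the scatter) in this assay. This is the first change in one place among these compounds, and it shows that inhibition at the tested concentration is sensitive to what sits on this oxygen, although compound 3 still gives 42.8% in this assay, so the change does not remove inhibition altogether. The data show the size of the fall but offer no measured explanation for it, and the loss of the hydrogen cannot be separated from the arrival of the ethyl group.

The compounds shown leave open whether the fall depends on the length of the group on this oxygen, which methoxy and a longer chain such as butoxy could help to show. They also leave open whether the oxygen itself can be replaced, for example by an amine in place of the hydroxy group, and how that would compare with compound 2 in this assay.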